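Benzyloxy for isopropoxy on a larger pyrazole acid

The compounds below may be only part of what the source reports. "The series", "measured", "known", "first", "only" and "open" are said of these compounds alone.

Compound 1 `CC(C)Oc1ccc(-c2cc(C(=O)O)nn2-c2ccc(C(C)C)cc2)cc1` and compound 2 `CC(C)c1ccc(-n2nc(C(=O)O)cc2-c2ccc(OCc3ccccc3)cc2)cc1` share one core. In an assay for displacement of a labelled ligand from Apoptosis regulator Bcl-2 (Homo sapiens), read by fluorescence polarization, with a stated time of 30 min (on this read-out lower numbers stand for stronger inhibition and higher numbers for weaker inhibition), compound 1 gives 5250 nM, while compound 2 gives 385 nM. The change between them, (benzyl in place of isopropyl on an oxygen on an aromatic ring), made a step of a 14-fold lower number from compound 1 to compound 2 (1.13 log units; beyond the scatter). Compound 3 `CC(C)Oc1ccc(C(=O)Nc2c(C(=O)O)nn(-c3ccc(Oc4ccccc4)cc3)c2-c2ccc(OC(C)C)cc2)cc1` gives 140 nM in this assay; the difference between its core and that of compound 1 is not broken down here. Compound 4 `CC(C)Oc1ccc(C(=O)Nc2c(C(=O)O)nn(-c3ccc(Oc4ccccc4)cc3)c2-c2ccc(OCc3ccccc3)cc2)cc1` differs from compound 3 by benzyl in place of isopropyl on an oxygen on an aromatic ring, the same change in the same place as that from compound 1 to compound 2. The step from compound 3 to compound 4 in this assay is expected to be a 5.6-fold lower number from compound 3 to compound 4 (0.75 log units; beyond the scatter), resting on the earlier step and tempered. The cores of compound 1 and compound 3 differ, and how much of the earlier step carries over to the core of compound 3 has not been measured. Compound 4 is estimated at 25 nM, between 6 nM and 100 nM.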

Compound 4, inhibition constant: > 10000 nM
Compound 4 was reported as a limit; the forecaster's own chance of this, stated with the estimate: 0%; middle value at least 400-fold (2.60 log units) from the limit.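

On the core of compound 3, the change from isopropoxy to benzyloxy gives an at least 71-fold higher number from compound 3 to compound 4 (1.85 log units; beyond the scatter) in this assay. Compound 4 is reported only as a limit of the assay, > 10000 nM, not as a number. The step therefore did not carry over between these two cores, though a single pair on each core does not show which difference between the cores matters: the same change on two cores in this assay, a 14-fold lower number (1.13 log units; beyond the scatter) from compound 1 to compound 2 and an at least 71-fold higher number (1.85 log units; beyond the scatter) from compound 3 to compound 4, at least 970-fold (2.98 log units) apart, beyond the scatter of two such steps.

The compounds shown leave open how the core of compound 3 responds to other groups on that oxygen, such as a longer chain or one ending in an amine. Going by these compounds, it also remains open whether any core intermediate between the two keeps the gain seen with benzyl.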